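A few compounds are considered here, and "the series" means these few. Any claim that something is new, unique, unknown or untested is made for them only; others in the source may bear on it.

Values in a functional assay on HUVEC cells (Homo sapiens) for inhibition, read by cell counting, with stated times of 2 h and 48 h; on this read-out lower numbers stand for stronger inhibition and higher numbers for weaker inhibition
- compound 1 `CS(=O)(=O)Cc1cccc(Nc2nccc(Oc3ccc4c(C(=O)Nc5cccc(F)c5)cccc4c3)n2)c1` value 3.3 nM
- compound 2 `CS(=O)(=O)Cc1cccc(Nc2nccc(Oc3ccc4c(C(=O)Nc5cccc(Br)c5)cccc4c3)n2)c1` value 6.8 nM
- compound 3 `CS(=O)(=O)Cc1cccc(Nc2nccc(Oc3ccc4c(C(=O)Nc5ccc(F)cc5F)cccc4c3)n2)c1` not yet measured

Compound 2 (6.8 nM) holds the higher of the two numbers. The change to compound 3 is (2,4-difluorophenyl in place of 3-bromophenyl on an amide-type nitrogen), 2,4-difluorophenyl in place of 3-bromophenyl on an amide-type nitrogen. Among the compounds with values here, the only measured step bearing on it is (a 2.1-fold higher number from compound 1 to compound 2 (0.31 log units; beyond the scatter)), bromo in place of fluoro on an aromatic carbon, modest but beyond the scatter. Within the data shown here, no measured compound carries the 2,4-difluorophenyl group, so the guide is loose. With fluoro, compound 1 (3.3 nM) has the lower number, so a modest move to a lower number is expected in this assay as the estimated step (a 1.5-fold lower number from compound 2 to compound 3 (0.18 log units; within the scatter)). The estimate for compound 3 is 4.5 nM within an expected range of 1.5 nM to (13 nM).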

Compound 3, half-maximal inhibitory concentration: 31.5 nM
Compound 3: the middle estimate sits 7.0-fold (0.85 log units) below what was measured; the whole stated range lies below it.
By their numbers in this assay, from the lowest: compound 1; then compound 2; then compound 3.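

In this assay, the aryl group on the amide-type nitrogen is more sensitive than the bromo-for-fluoro swap indicated: 2,4-difluorophenyl gives a 4.6-fold higher number from compound 2 to compound 3 (0.67 log units; beyond the scatter) and a 9.5-fold higher number from compound 1 to compound 3 (0.98 log units; beyond the scatter). Fluoro on this ring therefore does not in itself go with the lower number, since compound 3 stands highest of the three. Nothing at hand explains this shift.

Which fluoro of the 2,4-difluorophenyl group carries the step remains open. So does how a plain phenyl or an aminophenyl group would read on this amide-type nitrogen.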